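Benzyl Ester of Compound 1 in the Tail Flick Test

The compounds below may be only part of what the source reports. "The series", "measured", "known", "first", "only" and "open" are said of these compounds alone.

Three compounds sharing one core were measured in a functional assay on the whole organism (Tail, strain ICR) with Mus musculus as the target, in the tail flick test, with a stated time of 30 min, at a dose of 25 umol/kg by the oral route; a higher number here means a stronger effect of the compound at the dose given, a lower number a weaker effect. Compound 1 `CC[C@H](C)[C@H](NC(=O)CN(c1nc(Cl)nc2[nH]cnc12)C1CC1)C(=O)O` gives 30.3%, placing it second highest of the three numbers. Compound 2 `O=C(O)CNC(=O)CN(c1nc(Cl)nc2[nH]cnc12)C1CC1` gives 32.2%, and a number 1.9 percentage points higher from compound 1 to compound 2 (within the scatter) lies within the scatter, so the two cannot be ordered. Compound 3 `C[C@@H](O)[C@H](NC(=O)CN(c1nc(Cl)nc2[nH]cnc12)C1CC1)C(=O)O` gives 18.6%; here a number 11.7 percentage points lower from compound 1 to compound 3 (beyond the scatter) and a number 13.6 percentage points lower from compound 2 to compound 3 (beyond the scatter) are both beyond the scatter and modest in size.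

Compound 4 `CC[C@H](C)[C@H](NC(=O)CN(c1nc(Cl)nc2[nH]cnc12)C1CC1)C(=O)OCc1ccccc1` is not yet measured. It differs from compound 1 by benzyl in place of hydrogen on an oxygen next to a carbonyl group. Among the measured compounds shown here, none of the measured steps touches this oxygen: all three concern the saturated chain carbon bound to an amide-type nitrogen and a carbonyl carbon, or the chain that hangs from it. The measured steps therefore give no direct guide to the new change, and the closest the data come is that varying the side chain moved the number only modestly or not at all.

With nothing in the measured steps bearing on the change, compound 4 is expected to stay close to compound 1, and the estimated step is a number 0.3 percentage points lower from compound 1 to compound 4 (within the scatter). Compound 4 is thus estimated at 30%, within a range from 12% to 50%.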

Compound 4, a percentage reported as activity, at one dose (the size of the read-out at that dose, not a potency): 41.4%
Beside the measured number, compound 4's estimate is 11.4 percentage points below it; low and high end bracket the measured number.
By their numbers in this assay, from the lowest: compound 3; then compounds 1, 2 and 4 (each within the scatter of the next, the first and the last beyond it).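

In this assay, this oxygen proves to be a place where a change registers: with benzyl in place of hydrogen, the carboxy group becomes a benzyloxycarbonyl group and there is a number 11.1 percentage points higher from compound 1 to compound 4 (beyond the scatter), a step of modest size. The earlier compounds shown here varied only the side chain and left this oxygen untouched, so they could not show that the hydrogen on it can be replaced without losing the read-out at this dose, or that a change here can raise the number. Nothing at hand bears on why the number moves.

The compounds shown leave open whether this step belongs to the benzyl group in particular or to any ester at this oxygen, a question that a methyl ester or an ethyl ester would help to separate. They also leave open whether the same change would raise the number on the other side chains, as a benzyl ester of compound 2 or of compound 3 would show.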